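Replacing 4-fluorophenyl with 2-hydroxyphenyl on an amide-type nitrogen

The compounds below may be only part of what the source reports. "The series", "measured", "known", "first", "only" and "open" are said of these compounds alone.

Of the compounds shown here, two sharing one core have so far been measured in a functional assay on MCF7 cells (Homo sapiens) for inhibition, read by MTT assay; on this read-out higher numbers stand for weaker inhibition of growth and lower numbers for stronger inhibition of growth. Compound 1 (`CC1=C(/C=C/C(C)=C/C=C/C(C)=C\C(=O)NCc2cccc(F)c2)C(C)(C)CCC1n1ccnc1`) gives 1810 nM there, while compound 2 (`CC1=C(/C=C/C(C)=C/C=C/C(C)=C\C(=O)Nc2ccc(F)cc2)C(C)(C)CCC1n1ccnc1`) gives 400 nM and holds the lower of the two numbers. Compound 3 (`CC1=C(/C=C/C(C)=C/C=C/C(C)=C\C(=O)Nc2ccccc2O)C(C)(C)CCC1n1ccnc1`) differs from compound 2 in one place only, on an amide-type nitrogen (2-hydroxyphenyl in place of 4-fluorophenyl on an amide-type nitrogen). Here 2-hydroxyphenyl takes the place of 4-fluorophenyl. A single measured step bears on this change: a 4.5-fold lower number from compound 1 to compound 2 (0.66 log units; beyond the scatter) with 4-fluorophenyl in place of 3-fluorobenzyl on that same nitrogen. That modest step shows that the group on this nitrogen can move the number in this assay. Among the compounds with values here, it involves a different swap, however, and no measured compound carries the 2-hydroxyphenyl group, so it fixes no direction for the new change. Only a small drift away from the lower number of compound 2 is expected, and no clear step beyond the scatter. The estimated step is a 1.5-fold higher number from compound 2 to compound 3 (0.18 log units; within the scatter) and it remains uncertain. Compound 3 is expected at about 600 nM (estimated range 180 nM to 2000 nM).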

Compound 3, concentration for 50% growth inhibition: 1090 nM
Beside the measured number, compound 3's estimate is 1.8-fold (0.26 log units) below it; low and high end bracket the measured number.
By their numbers in this assay, from the lowest: compound 2; then compounds 3 and 1 (each within the scatter of the next).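

In this assay the swap on the amide-type nitrogen now has a measured step of its own, a 2.7-fold higher number from compound 2 to compound 3 (0.44 log units; beyond the scatter), and it lies beyond the scatter. A phenyl ring directly on this nitrogen is therefore not enough to keep the number of compound 2, which remains the lowest of the three: the result depends on what the ring carries, and here 2-hydroxyphenyl, with one hydrogen-bond donor and one acceptor, replaces 4-fluorophenyl, with neither. Set against the 3-fluorobenzyl group, the 2-hydroxyphenyl group gives no separation that can be read, with a 1.7-fold lower number from compound 1 to compound 3 (0.22 log units; within the scatter) lying within the scatter.

Nothing available explains why the number moves with this change. The swap alters both the substituent and its place on the ring, so these compounds cannot show which of the two matters, and they leave open how a phenyl ring carrying a methoxy group, an amine or a carboxylic acid on this nitrogen would read.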